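The source may hold more compounds than are shown below. What is called first, only, known or untested is meant among the compounds shown, and "the series" means these compounds.

Compounds measured in a functional assay on HEK293 cells for agonist activity at Neuronal acetylcholine receptor; alpha4/beta2 (Homo sapiens), read by FLIPR; a higher number here means that more compound is needed for the effect, a lower number that less compound is needed:
compound 1 `c1cncc(N2CC[C@@H]3CN[C@@H]3C2)c1` — 330 nM
compound 2 `COc1ccc(N2CC[C@@H]3CN[C@@H]3C2)cn1` — 4980 nM

Among the compounds with values here, compound 2 stands at the highest of the two numbers in this assay; its only neighbour is compound 1, and the step of a 15-fold higher number from compound 1 to compound 2 (1.18 log units; beyond the scatter) lies beyond the scatter. Within the data shown here, that step, methoxy in place of hydrogen on an aromatic carbon, is the only measured step, and it is large.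

Compound 3 `O=[N+]([O-])c1ccc(N2CC[C@@H]3CN[C@@H]3C2)cn1` is not yet measured. It differs from compound 2 by nitro in place of methoxy on an aromatic carbon. Among the measured compounds shown here, no measured pair swaps one substituent for another at this carbon, so the step of a 15-fold higher number from compound 1 to compound 2 (1.18 log units; beyond the scatter) is the only one that bears on the question, and what it shows is that occupying this carbon with a group raised the number by a large margin. Whether nitro in place of methoxy moves the number further or back cannot be read from the two numbers at hand. With the carbon occupied in both compounds, the expected step in this assay is a 1.2-fold higher number from compound 2 to compound 3 (0.08 log units; within the scatter), within the scatter. Compound 3 is therefore estimated at 6000 nM, in the range 1500 nM to 25000 nM.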

Compound 3, half-maximal effective concentration: 110 nM
For compound 3 the middle estimate is 55-fold (1.74 log units) above the measured one; the measured number lies below the stated range.
By their numbers in this assay, from the lowest: compound 3; then compound 1; then compound 2.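

In this assay, the earlier step of a 15-fold higher number from compound 1 to compound 2 (1.18 log units; beyond the scatter) could have been read as a cost of placing any group on this aromatic carbon next to the ring nitrogen, but the nitro compound rules that reading out: a 3.0-fold lower number from compound 1 to compound 3 (0.48 log units; beyond the scatter). Occupying the carbon therefore does not by itself raise the number, and the direction of the change from hydrogen depends on the group, with compound 1 lying between the two substituted compounds and beyond the scatter from each. The exchange of one group for the other, a 45-fold lower number from compound 2 to compound 3 (1.66 log units; beyond the scatter), is larger than either step from hydrogen, so the identity of the group at this carbon is a strong lever on the number in this series, though no measurement at hand says what underlies the opposite directions of methoxy and nitro.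

Within the data shown here, with only two groups at this carbon, no trend across groups can be drawn. From the compounds shown here alone, whether an amine, a nitrile or a chlorine here would follow nitro or methoxy remains open, as does whether nitro on another carbon of the ring would give a similar step.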